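This account rests on a few compounds, and the source may have more. Where it says the series, first, only, none or still open, it means among the compounds named here.

Measured compounds in the series:
compound 1 `COc1ccc(Cn2cc(CSC(=S)N3CCNCC3)nn2)cc1` — > 128000 nM
compound 2 `S=C(SCc1cn(Cc2ccc(Cl)c(Cl)c2)nn1)N1CCNCC1` — "not determined" (no result reported)
compound 3 `S=C(SCc1cn(Cc2ccccc2Cl)nn1)N1CCNCC1` — "not determined" (no result reported)

In a functional assay on PC-3 cells (Homo sapiens) for inhibition, read by MTT assay, with a stated time of 72 h (a higher number here means a weaker inhibitor, a lower number a stronger inhibitor), compound 1 gives > 128000 nM, which is a limit of the assay and not a number; this is the limit of > 128000 nM in this assay, at which 1 of the 3 values shown sits. Compound 2 gives "not determined" (no result reported) and compound 3 gives "not determined" (no result reported), so compound 3 stands without a number of its own, as does compound 2. Within the data shown here, no step between measured compounds is available.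

Compound 4 `CC(C)(C)OC(=O)N1CCN(C(=S)SCc2cn(Cc3ccccc3Cl)nn2)CC1` differs from compound 3 by tert-butoxycarbonyl in place of hydrogen on an amine nitrogen in a ring. Nothing measured bears on this change, so any step in this assay is expected only within the scatter, with no direction assigned. For compound 4 an inhibitory concentration of 50000 nM is estimated, between 8000 nM and 130000 nM.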

Compound 4, half-maximal inhibitory concentration: 12500 nM
Beside the measured number, compound 4's estimate is 4.0-fold (0.60 log units) above it; the range from low to high includes it.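

Among these compounds, compound 3 has no number of its own in this assay, so no step to compound 4 can be read. Whether tert-butoxycarbonyl in place of hydrogen on the ring nitrogen shifts inhibition stays open, and nothing shown accounts for the result of compound 4.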